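Glycine-to-alanine step and a proposed isoleucine-type analogue

The source may hold more compounds than are shown below. What is called first, only, known or untested is meant among the compounds shown, and "the series" means these compounds.

Measured so far in a functional assay on MDA-MB-231 cells (Homo sapiens) for cytotoxicity, read by MTT assay; a lower number here means a stronger inhibitor, a higher number a weaker inhibitor:
- compound 1 `CCCCCCCCC(CCCCCCCCC(=O)OC)SCC(=O)NCC(=O)OC`: 31400 nM
- compound 2 `CCCCCCCCC(CCCCCCCCC(=O)OC)SCC(=O)N[C@@H](C)C(=O)OC`: 98700 nM

Compound 2 stands at the higher of the two numbers; its nearest neighbour is compound 1, and the step of a 3.1-fold higher number from compound 1 to compound 2 (0.50 log units; beyond the scatter) is beyond the scatter. The proposed compound 3 `CCCCCCCCC(CCCCCCCCC(=O)OC)SCC(=O)N[C@H](C(=O)OC)[C@@H](C)CC` differs from compound 2 by sec-butyl in place of methyl on a saturated chain carbon bound to an amide-type nitrogen and a carbonyl carbon. Among the compounds with values here, only one measured step touches the same position, a 3.1-fold higher number from compound 1 to compound 2 (0.50 log units; beyond the scatter), which went to a weaker inhibitor when a small alkyl group entered at that carbon. Enlarging that group further is therefore expected to move the number in the same direction, by roughly a comparable or somewhat larger step, a 2.0-fold higher number from compound 2 to compound 3 (0.31 log units; beyond the scatter). On this basis compound 3 is estimated at 200000 nM, with a plausible range from 60000 nM to 600000 nM; a reading that reaches the upper limit of this assay cannot be excluded.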

Compound 3, half-maximal inhibitory concentration: 22400 nM
Estimate against measurement, compound 3: 8.9-fold (0.95 log units) above; the measured number lies below the stated range.
By their numbers in this assay, from the lowest: compounds 3 and 1 (each within the scatter of the next); then compound 2.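

In this assay, sec-butyl in place of methyl on the saturated chain carbon bound to an amide-type nitrogen and a carbonyl carbon gives a 4.4-fold lower number from compound 2 to compound 3 (0.64 log units; beyond the scatter) and so reverses the direction of a 3.1-fold higher number from compound 1 to compound 2 (0.50 log units; beyond the scatter) rather than extending it: the number does not track the size of the alkyl group at this carbon. Hydrogen and sec-butyl at this carbon cannot be told apart, with a 1.4-fold lower number from compound 1 to compound 3 (0.15 log units; within the scatter) within the scatter, and among these compounds only the methyl compound, compound 2, stands apart. No measured evidence on the origin of this behaviour is available.

Open, on these data alone, is whether an unbranched butyl chain or a benzyl group at this carbon would read like sec-butyl or like methyl. Also open, as far as these compounds go, is how the opposite configuration at this carbon, or a free carboxylic acid in place of the methyl ester on this fragment, would read.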